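This account rests on a few compounds, and the source may have more. Where it says the series, first, only, none or still open, it means among the compounds named here.

Compound 1, `COc1ccc(S(=O)(=O)N2CCc3cccc(NC(=O)c4ccc(C#N)cc4)c32)cc1`, gives 105 nM in a functional assay on KB cells (Homo sapiens) for cytotoxicity; a higher number here means a weaker inhibitor, a lower number a stronger inhibitor.
Compound 2, `COc1ccc(S(=O)(=O)N2CCc3cccc(NCc4ccccc4)c32)cc1`, gives > 10000 nM, which is a limit of the assay.
Compound 3, `COc1ccc(S(=O)(=O)N2CCc3cccc(NC(=O)c4cccs4)c32)cc1`, gives 47 nM.

Among the two numbers shown, compound 3 stands lowest; its nearest neighbour is compound 1, with a 2.2-fold lower number from compound 1 to compound 3 (0.35 log units; beyond the scatter). Compound 4, `COc1ccc(S(=O)(=O)N2CCc3cccc(NC(=O)N(C)c4ccccc4)c32)cc1`, differs from compound 3 in one place: methyl(phenyl)amino in place of thiophen-2-yl on a carbonyl carbon. Within the data shown here, two measured steps bear on this. Swapping the ring on the carbonyl carbon gave a 2.2-fold lower number from compound 1 to compound 3 (0.35 log units; beyond the scatter), a modest change. Removing the carbonyl altogether gave an at least 95-fold higher number from compound 1 to compound 2 (1.97 log units; beyond the scatter), a large loss, with compound 2 sitting at the limit of > 10000 nM in this assay, at which 1 of the 3 values shown sits. Compound 4 keeps the carbonyl and changes only what sits on it, so a modest step is expected, likely toward a higher number. For compound 4 the expected result is 150 nM, within 30 nM to 1500 nM, which means a 3.2-fold higher number from compound 3 to compound 4 (0.50 log units; beyond the scatter).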

Compound 4, half-maximal inhibitory concentration: > 10000 nM
Compound 4 was reported as a limit; the forecaster's own chance of this, stated with the estimate: 10%; at least 66-fold (1.82 log units) between middle value and limit.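

Keeping the carbonyl is not enough to hold activity. Methyl(phenyl)amino on the carbonyl carbon gives an at least 210-fold higher number from compound 3 to compound 4 (2.32 log units; beyond the scatter), and likewise an at least 95-fold higher number from compound 1 to compound 4 (1.97 log units; beyond the scatter), a loss on the scale seen earlier only when the carbonyl itself was removed, so the group on this carbon can decide the result. Compound 2 and compound 4 both sit at a limit, and the step between them cannot be read: the limit of > 10000 nM in this assay, at which 2 of the 4 values shown sit.

Going by these compounds, whether the loss follows from the methyl or from the phenyl stays open. Phenylamino, which lacks the methyl, or dimethylamino, which lacks the ring, on this carbonyl carbon would separate the two.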